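The compounds below may be only part of what the source reports. "The series", "measured", "known", "first", "only" and "open" are said of these compounds alone.

Compound 1 `COc1cccc(Oc2ccc3cc(NC(=O)c4ccc(OC)c(-c5cccc(OC)c5)c4)c(=O)oc3c2C)c1`: in a functional assay on SK-BR-3 cells (Homo sapiens) for antiproliferative activity (on this read-out higher numbers stand for weaker inhibition and lower numbers for stronger inhibition), compound 1 gives > 100000 nM, which is a limit of the assay and not a number.
Compound 2 `COc1ccc(Nc2ccc3cc(NC(=O)c4ccc(OC(C)=O)c(CC=C(C)C)c4)c(=O)oc3c2C)cc1`: in this assay compound 2 gives > 100000 nM, likewise a limit.
Compound 3 `COc1ccc(Nc2ccc3cc(NC(=O)c4ccc(O)c(CC=C(C)C)c4)c(=O)oc3c2C)cc1`: in this assay compound 3 gives > 100000 nM, again a limit.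

Compound 1 therefore stands on a limit only, with no measured number beneath it, and the same holds for the two other compounds, all three sitting at the limit of > 100000 nM in this assay, at which 3 of the 3 values shown sit. The change from compound 1 to compound 4 `COc1cccc(-c2cc(C(=O)Nc3cc4ccc(Cc5ccccc5)c(C)c4oc3=O)ccc2OC)c1` is benzyl in place of 3-methoxyphenoxy on an aromatic carbon. For the measured compounds named here, only one measured step exists, a step that the two limits leave unreadable from compound 2 to compound 3, and it cannot be read because the limit of > 100000 nM in this assay, at which 3 of the 3 values shown sit, holds both of its ends; it concerns a different group in a different place and gives no size that carries over. No measured step thus bears on the change to compound 4, and no direction can be drawn from the data shown. The step of an at least 1.1-fold lower number from compound 1 to compound 4 (0.04 log units; that floor lies within the scatter) is accordingly expected to stay unreadable, with compound 4 most likely again reported only as a limit. Compound 4 is estimated at 90000 nM, with a range from 8000 nM to 300000 nM.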

Compound 4, half-maximal inhibitory concentration: 4090 nM
Compound 4: the middle estimate sits 22-fold (1.34 log units) above what was measured; measured number below the stated range.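

At this aromatic carbon, ortho to a methyl group, benzyl in place of 3-methoxyphenoxy gives an at least 24-fold lower number from compound 1 to compound 4 (1.38 log units; beyond the scatter) in this assay, the first readable step among these compounds. Both groups carry one six-membered aromatic ring of carbon only, so the position responds to a change that keeps this ring while the entering group has 0 hydrogen-bond acceptors against 2 in the group that leaves. Compound 2 and compound 3 stay on a limit, so the step between them still cannot be read: the limit of > 100000 nM in this assay, at which 3 of the 4 values shown sit.

The change alters the link to the ring and removes the methoxy group together, so the compounds shown do not tell these two apart. A 3-methoxybenzyl or unsubstituted phenoxy group would separate them, and a phenethyl chain would test whether a longer link is tolerated.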